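A few compounds are considered here, and "the series" means these few. Any claim that something is new, unique, unknown or untested is made for them only; others in the source may bear on it.

In a functional assay on HepG2 cells (Homo sapiens) for antiproliferative activity, read by fluorescence and resazurin assay, with a stated time of 48 h (on this read-out higher numbers stand for weaker inhibition and lower numbers for stronger inhibition), compound 3 (`O=C(N/N=C/c1cc2ccccc2nc1Cl)c1cc2cc(Br)ccc2oc1=O`) gives 9420 nM. This is within the scatter of compound 1 (`CCOc1ccc2nc(Cl)c(/C=N/NC(=O)c3cc4cc([N+](=O)[O-])ccc4oc3=O)cc2c1`) at 18100 nM. The gap to compound 2 lies beyond the scatter: compound 2 (`CCOc1ccc2nc(Cl)c(/C=N/NC(=O)c3cc4ccccc4oc3=O)cc2c1`) has a higher number at 33100 nM. Compound 4 (`CCOc1ccc2nc(Cl)c(/C=N/NC(=O)c3cc4cc(Br)ccc4oc3=O)cc2c1`) differs from compound 3 by ethoxy in place of hydrogen on an aromatic carbon. Going by the values given here, no measured step tests this change directly. The only one, a 1.8-fold higher number from compound 1 to compound 2 (0.26 log units; within the scatter), concerns a different substitution. Compound 1 and compound 2 both carry ethoxy, which gives indirect support for a small rise in this assay. The expected step is a 1.6-fold higher number from compound 3 to compound 4 (0.20 log units; within the scatter), and it may not clear the scatter. For compound 4 the estimated value is 15000 nM, with an expected range of 7000 nM to 32000 nM.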

Compound 4, half-maximal inhibitory concentration: 29000 nM
For compound 4 the middle estimate is 1.9-fold (0.29 log units) below the measured one; measured number inside the range.
By their numbers in this assay, from the lowest: compounds 3, 1, 4 and 2 (each within the scatter of the next, the first and the last beyond it).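

Ethoxy in place of hydrogen on an aromatic carbon now has a direct reading in this assay (a 3.1-fold higher number from compound 3 to compound 4 (0.49 log units; beyond the scatter)), a modest step beyond the scatter with bromo held constant. With ethoxy present, swapping the other substituent stays within the scatter, both for bromo against hydrogen (a 1.1-fold lower number from compound 2 to compound 4 (0.06 log units; within the scatter)) and for bromo against nitro (a 1.6-fold higher number from compound 1 to compound 4 (0.20 log units; within the scatter)). No measured evidence accounts for the ethoxy step.

Going by these compounds, whether methoxy or an amine on this carbon would match ethoxy remains open. So does whether the ethoxy step holds with nitro or hydrogen instead of bromo.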